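The source may hold more compounds than are shown below. What is called first, only, known or untested is meant among the compounds shown, and "the series" means these compounds.

In a functional assay on the whole organism for inhibition, with Mus musculus as the target (a lower number here means that less compound is needed, a higher number that more compound is needed for the effect), three compounds sharing one core have been measured. Compound 1 `CCNC(=O)Nc1cccc2c1CN(C)CC2c1ccccc1` gives 80 mg/kg. Compound 2 `CCCNC(=O)Nc1cccc2c1CN(C)CC2c1ccccc1` reads > 80 mg/kg, which is a limit of the assay and not a number. Compound 3 `CN1Cc2c(NC(=O)OCc3ccccc3)cccc2C(c2ccccc2)C1` gives about 15 mg/kg, the lowest number of the three. Compound 4 `CC(C)NCC(=O)Nc1cccc2c1CN(C)CC2c1ccccc1` carries (isopropylamino)methyl in place of benzyloxy on a carbonyl carbon. Within the data shown here, no measured step makes this exact exchange. The closest evidence is the pair of steps that introduce benzyloxy on that carbonyl carbon: a 5.3-fold lower number from compound 1 to compound 3 (0.73 log units; beyond the scatter) and an at least 5.3-fold lower number from compound 2 to compound 3 (0.72 log units; beyond the scatter). Both are beyond the scatter, and compound 4 gives up the same benzyloxy group. Read in reverse, those steps point towards a higher number, although the entering group is neither ethylamino nor propylamino, so their size carries over only loosely. A modest rise is therefore expected, a 3.3-fold higher number from compound 3 to compound 4 (0.52 log units; beyond the scatter). For compound 4 the estimated value is 50 mg/kg, with an expected range from 15 mg/kg to 150 mg/kg.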

Compound 4, dose for half-maximal effect: 14 mg/kg
For compound 4 the middle estimate is 3.6-fold (0.55 log units) above the measured one, and the stated range ends above it.
By their numbers in this assay, from the lowest: compounds 4 and 3 (each within the scatter of the next); then compound 1.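

With a 1.1-fold lower number from compound 3 to compound 4 (0.03 log units; within the scatter) in this assay, (isopropylamino)methyl on the carbonyl carbon matches benzyloxy, so at this position a low number does not depend on benzyloxy or its six-membered aromatic ring. The same entering group, set against ethylamino, gives a 5.7-fold lower number from compound 1 to compound 4 (0.76 log units; beyond the scatter), so the lower number reached with benzyloxy is no longer tied to that one group, and two quite different groups now stand apart from ethylamino. Against propylamino the step is an at least 5.7-fold lower number from compound 2 to compound 4 (0.75 log units; beyond the scatter), and it rests on a limit of the assay and not a number: the limit of > 80 mg/kg in this assay, at which 1 of the 4 values shown sits.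

The compounds shown leave open whether the nitrogen of (isopropylamino)methyl matters here, a question that an all-carbon isobutyl group on the same carbonyl carbon would address. From the compounds shown here alone, it also remains open how a tertiary amine such as dimethylaminomethyl, or a longer chain between the carbonyl and the amine, would read in this assay.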